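The source may hold more compounds than are shown below. What is called first, only, known or untested is meant among the compounds shown, and "the series" means these compounds.

Of the compounds shown here, two of the same core have been measured so far. Compound 1 `O=C1N=C(N2N=C(c3ccccc3)CC2c2ccccc2O)S/C1=C1/C(=O)Nc2ccccc21` gives 1990 nM in a functional assay on cells (Cancer cell lines, Homo sapiens) for cytotoxicity, read by sulforhodamine B assay, with a stated time of 48 h; on this read-out lower numbers stand for stronger inhibition of growth and higher numbers for weaker inhibition of growth. Compound 2 `COc1ccc(C2CC(c3ccccc3)=NN2C2=NC(=O)/C(=C3\C(=O)Nc4ccccc43)S2)cc1` gives 1810 nM in this assay. The one measured step, a 1.1-fold lower number from compound 1 to compound 2 (0.04 log units; within the scatter), concerns the group on a saturated ring carbon and lies within the scatter, so on the numbers shown compound 2 and compound 1 cannot be told apart; compound 2 simply stands with the other as one of two very similar results.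

Compound 3 `COc1ccc(C2CC(c3ccc4ccccc4c3)=NN2C2=NC(=O)/C(=C3\C(=O)Nc4ccccc43)S2)cc1` is the next one to be tested. It differs from compound 2 in one place: naphthalen-2-yl in place of phenyl on a carbon with a double bond to nitrogen. Among the measured compounds shown here, no measured step touches this position, since the only step recorded changes a different ring substituent and was itself within the scatter. With nothing in the data pointing either way, the expectation is a step from compound 2 to compound 3 of a 1.1-fold lower number from compound 2 to compound 3 (0.05 log units; within the scatter), that is, no change beyond the scatter. Compound 3 is therefore estimated to give about 1600 nM in this assay, with a likely range from 600 nM to 4500 nM.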

Compound 3, concentration for 50% growth inhibition: 1680 nM
Beside the measured number, compound 3's estimate is 1.1-fold (0.02 log units) below it; the range from low to high includes it.
By their numbers in this assay, from the lowest: compounds 3, 2 and 1 (each within the scatter of the next).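

Placing naphthalen-2-yl where compound 2 has phenyl, on the carbon with a double bond to nitrogen, brings a 1.1-fold lower number from compound 2 to compound 3 (0.03 log units; within the scatter) in this assay, so on these numbers compound 2 and compound 3 cannot be told apart. Among the compounds shown here, this is the first look at this position, and it shows that a group of two aromatic rings can stand there in place of a single ring with no difference in growth inhibition beyond the scatter. No other measurement is available that could explain this result.

All groups shown at this position are aromatic rings of carbon only, so it remains open whether a different kind of group, such as a phenyl ring bearing an amine or a carboxylic acid, or a short alkyl chain in place of the ring, would give a number outside the scatter. It is also open whether naphthalen-2-yl would give the same result alongside the 2-hydroxyphenyl group of compound 1, and no group shown so far separates any of the compounds from the others.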